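Fluoro for Methyl in a Cytotoxicity Series

A few compounds are considered here, and "the series" means these few. Any claim that something is new, unique, unknown or untested is made for them only; others in the source may bear on it.

Of the compounds shown here, three sharing one core have been measured in a functional assay on U-937 cells (Homo sapiens) for cytotoxicity; a lower number here means that less compound is tolerated, a higher number that more compound is tolerated. Compound 1 `Clc1ccc(OC(CCn2ccnc2)c2ccccc2)cc1` gives 84900 nM there. Compound 3 `Fc1ccc(OC(CCn2ccnc2)c2ccccc2)c(F)c1` gives 219000 nM in this assay. Compound 2 `Cc1ccc(C(CCn2ccnc2)Oc2ccc(Cl)cc2Cl)cc1` gives 40000 nM, the lowest of the three numbers; its gap to compound 1 and its larger gap to compound 3 both lie beyond the usual scatter. Compound 4 `Fc1ccc(C(CCn2ccnc2)Oc2ccc(Cl)cc2Cl)cc1` has not yet been measured. It differs from compound 2 by fluoro in place of methyl on an aromatic carbon. Among the measured compounds shown here, no measured pair shows this change on its own, so the expectation rests on compound 2 alone. The step of a 1.4-fold higher number from compound 2 to compound 4 (0.14 log units; within the scatter) is expected to be small and probably not beyond the scatter. Compound 4 is therefore estimated at 55000 nM, within a range from 20000 nM to 150000 nM.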

Compound 4, half-maximal cytotoxic concentration: 43300 nM
Estimate against measurement, compound 4: 1.3-fold (0.10 log units) above; the range from low to high includes it.
By their numbers in this assay, from the lowest: compounds 2, 4 and 1 (each within the scatter of the next, the first and the last beyond it); then compound 3.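

Among the compounds shown here, the change from 4-methylphenyl to 4-fluorophenyl gives a 1.1-fold higher number from compound 2 to compound 4 (0.03 log units; within the scatter) in this assay and is the first measured step. At this place, on an aromatic carbon para to a large group, the data therefore do not distinguish fluoro from methyl. Nothing measured here offers an explanation for this result. The compounds shown leave open whether a larger change at this place, such as an amine, a carboxylic acid or a longer chain, would produce a step beyond the scatter.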